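Replacing 2,4-dichlorophenyl with pyridin-2-yl on a shared core

The source may hold more compounds than are shown below. What is called first, only, known or untested is meant among the compounds shown, and "the series" means these compounds.

Compounds that share one core can be compared by changing a single group and watching what happens to the number. In an ADME assay on Vero cells (Chlorocebus sabaeus) for cytotoxicity, read by MTT assay, with a stated time of 72 h (on this read-out lower numbers stand for higher toxicity in this test and higher numbers for lower toxicity in this test), compound 1 `CC1(C)C=Cc2c(ccc(C(=O)/C=C/c3ccc(F)cc3)c2O)O1` gives 158000 nM. For compound 2 `CC1(C)C=Cc2c(ccc(C(=O)/C=C/c3ccc(Br)cc3)c2O)O1` the entry reads "not determined" (no result reported), so it offers no number for comparison. Compound 3 `CC1(C)C=Cc2c(ccc(C(=O)/C=C/c3ccc(Cl)cc3Cl)c2O)O1` gives 131000 nM, level with compound 1 once the usual scatter of repeated measurements is allowed for. For the measured compounds named here, with only two numbers available, neither can be ranked above the other.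

The next structure is compound 4 `CC1(C)C=Cc2c(ccc(C(=O)/C=C/c3ccccn3)c2O)O1`, and the change is pyridin-2-yl in place of 2,4-dichlorophenyl on a double-bonded chain carbon bound to a double-bonded chain carbon. The group that leaves has a ring of carbon only, while the group that enters has a six-membered aromatic ring with 1 hetero atom.

Going by the values given here, only one measured step touches this place on the chain: a 1.2-fold lower number from compound 1 to compound 3 (0.08 log units; within the scatter). Both of its groups have rings of carbon only, so it is an indirect guide to the new ring. It still gives no reason to expect a real shift in either direction, so the range has to stay wide. The expected change is a 1.1-fold higher number from compound 3 to compound 4 (0.06 log units; within the scatter), which would not stand beyond the scatter. For compound 4 the estimated value in this assay is 150000 nM, with an expected range from 70000 nM to 320000 nM.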

Compound 4, half-maximal cytotoxic concentration: 20500 nM
For compound 4 the middle estimate is 7.3-fold (0.86 log units) above the measured one; the measured number lies below the stated range.
By their numbers in this assay, from the lowest: compound 4; then compounds 3 and 1 (each within the scatter of the next).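

This place on the chain is not indifferent to the ring it carries: in this assay there is a 6.4-fold lower number from compound 3 to compound 4 (0.81 log units; beyond the scatter) and also a 7.7-fold lower number from compound 1 to compound 4 (0.89 log units; beyond the scatter) when pyridin-2-yl enters. For the compounds shown here, the two rings of carbon only, 2,4-dichlorophenyl and 4-fluorophenyl, gave numbers within the scatter of each other, so the earlier compounds gave no sign that this place could matter. Since a lower number stands for higher toxicity in this test, compound 4 is the most toxic of the three compounds with a number, and nothing measured here explains the shift.

The change from 2,4-dichlorophenyl to pyridin-2-yl removes both chlorine atoms and brings in a ring nitrogen in a single step, so the compounds shown cannot tell which of the two goes with the lower number. Plain phenyl, a ring of carbon only with no halogen, would help to separate the two, while pyridin-3-yl or pyridin-4-yl would show whether the place of the nitrogen in the ring matters, and a pyridin-2-yl ring carrying an amine would show whether the lower number survives further change.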